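Amide to aryl swap at the ring nitrogen: compound 2 to compound 3

The compounds below may be only part of what the source reports. "The series", "measured", "known", "first", "only" and "open" are said of these compounds alone.

Measured so far in a functional assay on PC-3 cells (Homo sapiens) for inhibition, read by MTT assay, with a stated time of 48 h; on this read-out higher numbers stand for weaker inhibition and lower numbers for stronger inhibition:
Compound 1 `COc1cc(-c2nc3cc(/C=C4\SC(=O)N(CC(=O)N5CCCCC5)C4=O)ccc3[nH]2)cc(OC)c1OC`: 14700 nM
Compound 2 `COc1cc(-c2nc3cc(/C=C4\SC(=O)N(CC(=O)N5CCCC5)C4=O)ccc3[nH]2)cc(OC)c1OC`: 8370 nM

Compound 2 and compound 1 lie within the scatter of each other, a 1.8-fold lower number from compound 1 to compound 2 (0.24 log units; within the scatter), so neither number separates from the other on this pair alone; compound 2 simply carries the lower of the two readings without that difference meaning anything.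

Compound 3 `COc1cc(CN2C(=O)S/C(=C\c3ccc4[nH]c(-c5cc(OC)c(OC)c(OC)c5)nc4c3)C2=O)cc(OC)c1OC` is not yet measured. It differs from compound 2 as follows: 3,4,5-trimethoxyphenyl in place of (pyrrolidin-1-yl)carbonyl on a saturated chain carbon bound to an amide-type nitrogen in a ring. Going by the values given here, the one measured step, a 1.8-fold lower number from compound 1 to compound 2 (0.24 log units; within the scatter), concerns only the size of the saturated ring on the amide carbonyl and leaves the carbonyl in place; it does not touch the change made here, where the carbonyl and its ring are gone and an aromatic ring enters instead. No measured step therefore bears directly on compound 3, and no direction in this assay can be read from the pair shown.

The working expectation for compound 3 is accordingly a number close to that of compound 2, a 1.0-fold lower number from compound 2 to compound 3 (0.02 log units; within the scatter), with a wide range to reflect the absent precedent. Compound 3 is estimated at 8000 nM, between 2500 nM and 25000 nM.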

Compound 3, half-maximal inhibitory concentration: 10200 nM
Compound 3: middle estimate off by 1.3-fold (0.11 log units), on the low side; low and high end bracket the measured number.
By their numbers in this assay, from the lowest: compounds 2, 3 and 1 (each within the scatter of the next).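

In this assay, the exchange of the amide for an aromatic ring on the saturated chain carbon bound to an amide-type nitrogen in a ring gives a 1.2-fold higher number from compound 2 to compound 3 (0.09 log units; within the scatter) when 3,4,5-trimethoxyphenyl replaces (pyrrolidin-1-yl)carbonyl, and a 1.4-fold lower number from compound 1 to compound 3 (0.16 log units; within the scatter) when it replaces (piperidin-1-yl)carbonyl. Going by these compounds alone, until now only the size of the saturated ring had been varied, so these are the first readings at this position without the carbonyl, and neither step separates from the scatter: on these three compounds, the amide and the 3,4,5-trimethoxyphenyl group cannot be told apart on this read-out. Nothing measured alongside these readings accounts for their closeness.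

Open, going by these compounds, is whether any group at this place moves the number beyond the scatter, for instance a carboxylic acid, an amine, or a plain phenyl ring without the three methoxy groups. Also open, on these data alone, is whether a longer chain between the ring nitrogen and the 3,4,5-trimethoxyphenyl group would separate from compound 3 in this assay.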